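Aryl alkyne variation and maximal response at the receptor

This account rests on a few compounds, and the source may have more. Where it says the series, first, only, none or still open, it means among the compounds named here.

Two compounds have been measured in an ADME assay on HEK293 cells for agonist activity at metabotropic glutamate receptor 5 (Rattus norvegicus), read by fluorescence and calcium flux; a higher number here means a larger maximal response, a lower number a smaller maximal response:

compound 1, `Cc1cccc(C#Cc2ccc(C(=O)N[C@H](C)C(C)(C)O)nc2)c1`, gives 20.8%
compound 2, `C[C@@H](NC(=O)c1ccc(C#Cc2cccnc2)cn1)C(C)(C)O`, gives 25.9%

Of the two numbers, compound 2 is the one nominally on top, but the step of a number 5.1 percentage points higher from compound 1 to compound 2 (within the scatter) lies within the scatter, so the two values are not separated by the assay. Going by the values given here, that single step is the only comparison available, and it concerns the same place in the molecule that changes next: the group on the triple-bonded carbon.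

Compound 3, `C[C@@H](NC(=O)c1ccc(C#Cc2ccc(F)cn2)cn1)C(C)(C)O`, differs from compound 2 in exactly that place: 5-fluoropyridin-2-yl in place of pyridin-3-yl on a triple-bonded carbon. Among the compounds with values here, the one measured step bearing on this change, the exchange on the same triple-bonded carbon from compound 1 to compound 2, stayed within the scatter. On that basis compound 3 is expected to show a step of a number 0.9 percentage points lower from compound 2 to compound 3 (within the scatter) from compound 2 in this assay, that is, no change beyond the scatter in either direction. The estimate for compound 3 is therefore 25%, with a range from 12% to 40%.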

Compound 3, largest response reached (reported as efficacy), in percent of the reference or control that the assay uses: 13.5%
Compound 3: the middle estimate sits 11.5 percentage points above what was measured; the measured number falls inside the stated range.
By their numbers in this assay, from the lowest: compounds 3, 1 and 2 (each within the scatter of the next, the first and the last beyond it).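

In this assay, the group on the triple-bonded carbon can move the maximal response beyond the scatter: 5-fluoropyridin-2-yl in place of pyridin-3-yl gives a number 12.4 percentage points lower from compound 2 to compound 3 (beyond the scatter), a modest step and the first in this short series to clear it. The separation is only partial, since 5-fluoropyridin-2-yl in place of 3-methylphenyl gives a number 7.3 percentage points lower from compound 1 to compound 3 (within the scatter), which leaves compound 1 unresolved from both compound 2 and compound 3, so the three groups do not fall into clearly separate levels. Nothing at hand accounts for the step from compound 2 to compound 3.

This exchange changes the ring's point of attachment and adds a fluorine in a single step, so the compounds shown cannot assign the step to either change. From the compounds shown here alone, it remains open whether a plain pyridin-2-yl or a 5-chloropyridin-2-yl on the triple-bonded carbon would read like compound 3 or like compound 2, and how a saturated group such as cyclohexyl would behave in that place.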